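Compound 3 to compound 4: cyano gives way to ethoxycarbonyl

A few compounds are considered here, and "the series" means these few. Any claim that something is new, unique, unknown or untested is made for them only; others in the source may bear on it.

In an ADME assay on MT4 cells (Homo sapiens) for cytotoxicity (a higher number here means that more compound is tolerated, a lower number that less compound is tolerated), compound 3 (`N#Cc1ccc(NC(=S)Nc2cccc(C(F)(F)F)c2)cc1`) gives 7000 nM, level with compound 1 (`FC(F)(F)c1cccc(NC(=S)Nc2ccc(Cl)cc2)c1`) at 6800 nM. Both sit under compound 2 (`CCCC[C@H]1CC[C@H](c2ccc(NC(=S)Nc3cccc(C(F)(F)F)c3)cc2)CC1`), which gives 22000 nM.

Compound 4 (`CCOC(=O)c1ccc(NC(=S)Nc2cccc(C(F)(F)F)c2)cc1`) keeps the shared core of compound 3 but carries ethoxycarbonyl in place of cyano on an aromatic carbon, para to a large group (ethoxycarbonyl in place of cyano on an aromatic carbon).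

For the measured compounds named here, three measured steps bear on this place. Cyano in place of chloro gave a 1.0-fold higher number from compound 1 to compound 3 (0.01 log units; within the scatter), so that exchange left the number within the scatter. 4-Butylcyclohexyl in place of chloro gave a 3.2-fold higher number from compound 1 to compound 2 (0.51 log units; beyond the scatter), and cyano in place of 4-butylcyclohexyl gave a 3.1-fold lower number from compound 2 to compound 3 (0.50 log units; beyond the scatter), both modest. No ester has been measured, so these steps offer only a rough guide. Ethoxycarbonyl is a much smaller substituent than the 4-butylcyclohexyl of compound 2, so a step smaller than those modest ones is expected.

The estimated change is slight and upward, a 1.2-fold higher number from compound 3 to compound 4 (0.08 log units; within the scatter), and would probably stay within the scatter. For compound 4 the expected value is 8500 nM, with an estimated range of 3500 nM to 20000 nM.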

Compound 4, half-maximal cytotoxic concentration: 23000 nM
Estimate against measurement, compound 4: 2.7-fold (0.43 log units) below; the whole stated range lies below it.
By their numbers in this assay, from the lowest: compounds 1 and 3 (each within the scatter of the next); then compounds 2 and 4 (each within the scatter of the next).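

In this assay, this position proves more responsive than the level pair of chloro and cyano suggested: ethoxycarbonyl in place of cyano gives a modest rise (a 3.3-fold higher number from compound 3 to compound 4 (0.52 log units; beyond the scatter)), and ethoxycarbonyl in place of chloro gives a rise of about the same size (a 3.4-fold higher number from compound 1 to compound 4 (0.53 log units; beyond the scatter)). A ringless group is therefore enough to reach the level of compound 2, since ethoxycarbonyl in place of 4-butylcyclohexyl leaves the number within the scatter (a 1.0-fold higher number from compound 2 to compound 4 (0.02 log units; within the scatter)), and the higher numbers at this place do not depend on a ring-bearing substituent. No measurement shown accounts for this result.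

The compounds shown leave open whether a carboxylic acid, an amide or a longer-chain ester at this place would match ethoxycarbonyl. They also leave open whether the number would climb further with any other group here.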